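This account rests on a few compounds, and the source may have more. Where it says the series, first, only, none or still open, it means among the compounds named here.

Compound 1 `O=C(/C=C\Nc1ccc(F)cc1)c1cn(-c2ccccc2)nc1-c1ccc(F)cc1` and compound 2 `O=C(/C=C\Nc1ccc(F)cc1)c1cn(-c2ccccc2)nc1-c1ccc(Cl)cc1` share one core, and compound 3 `COc1cc(-c2nn(-c3ccccc3)cc2C(=O)/C=C\Nc2ccc(F)cc2)cc(OC)c1OC` and compound 4 `COc1cc(-c2nn(-c3ccccc3)cc2C(=O)/C=C\Nc2ccc(Cl)cc2)cc(OC)c1OC` share another; the difference between the two cores is not broken down here. In a functional assay on U-87MG ATCC cells (Homo sapiens) for antiproliferative activity, read by MTT assay, with a stated time of 48 h (on this read-out lower numbers stand for stronger inhibition and higher numbers for weaker inhibition), compound 1 gives 18200 nM, and compound 2 gives 17900 nM. The step from compound 1 to compound 2 is chloro in place of fluoro on an aromatic carbon, and it made a change of a 1.0-fold lower number from compound 1 to compound 2 (0.01 log units; within the scatter). In this assay compound 3 gives 4780 nM, the lowest of the three numbers and beyond the scatter from both compound 1 and compound 2.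

Compound 4 differs from compound 3 by chloro in place of fluoro on an aromatic carbon, the same change that separates compound 1 and compound 2, made in the same kind of place. With compound 3 as the starting point, the expectation for compound 4 is a step of about a 1.0-fold lower number from compound 3 to compound 4 (0.02 log units; within the scatter), because the same change gave a 1.0-fold lower number from compound 1 to compound 2 (0.01 log units; within the scatter) on the first core. Compound 4 is therefore estimated at 4600 nM, with a likely range from 2500 nM to 9000 nM.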

Compound 4, half-maximal inhibitory concentration: 3210 nM
Beside the measured number, compound 4's estimate is 1.4-fold (0.16 log units) above it; the range from low to high includes it.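

In this assay, going from fluoro to chloro on the second core gives a 1.5-fold lower number from compound 3 to compound 4 (0.17 log units; within the scatter), so this step stays within the usual scatter of repeated measurements. Within the data shown here, the two steps on the two cores agree, and in these two pairs the swap carries from one core to the other without a measurable difference: the same change on two cores in this assay, a 1.0-fold lower number (0.01 log units; within the scatter) from compound 1 to compound 2 and a 1.5-fold lower number (0.17 log units; within the scatter) from compound 3 to compound 4, 1.5-fold (0.17 log units) apart, within the scatter of two such steps This does not show a general rule, since it rests on only two pairs in one assay, and the swap does not sit on the same ring in both: compound 3 and compound 4 differ in (4-fluorophenyl)amino versus (4-chlorophenyl)amino, a group that compound 1 and compound 2 share unchanged.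

The compounds shown leave open whether a bromo, methyl or methoxy group in that place, or simply a hydrogen, would also stay within the scatter. They also leave open whether a larger group, such as a morpholine ring, would give a step beyond it.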